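The source may report more compounds than this note shows. Statements on the series, on what has been measured and on what is new or still open speak of the compounds shown alone.

Measured in an ADME assay on NHDF cells (Homo sapiens) for cytotoxicity, read by MTT assay, with a stated time of 72 h; a higher number here means a weaker inhibitor, a lower number a stronger inhibitor:
- Compound 1 `COc1cccc(/C=C2\CCC/C(=C\c3cc(Cl)cc(Cl)c3)C2=O)c1OC`: 21600 nM
- Compound 2 `COc1ccc(/C=C2\CCC/C(=C\c3cccc(Cl)c3)C2=O)cc1OC`: 11900 nM

Compound 2 stands level with compound 1, since their two numbers lie within the usual scatter of repeated measurements. Compound 3 `COc1ccc(/C=C2\CCC/C(=C\c3ccc(Br)cc3)C2=O)cc1OC` has not yet been measured. It carries 4-bromophenyl in place of the 3-chlorophenyl of compound 2, on a double-bonded chain carbon bound to a double-bonded ring carbon (4-bromophenyl in place of 3-chlorophenyl on a double-bonded chain carbon bound to a double-bonded ring carbon).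

Going by the values given here, no two measured compounds differ in just one place, so no measured step speaks directly to this change. Still, compound 1 at 21600 nM and compound 2 at 11900 nM differ in more than one place and remain within the scatter. No step beyond the scatter is therefore expected in this assay. The expected change is small, a 1.1-fold lower number from compound 2 to compound 3 (0.03 log units; within the scatter). For compound 3 the estimated value is 11000 nM, with an expected range of 5000 nM to 24000 nM.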

Compound 3, half-maximal inhibitory concentration: 13100 nM
Estimate against measurement, compound 3: 1.2-fold (0.08 log units) below, and the stated range covers the measured number.
By their numbers in this assay, from the lowest: compounds 2, 3 and 1 (each within the scatter of the next).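

Going by these compounds alone, this is the first pair here that differs in one place only, so it gives the first direct reading of this position: in this assay there is a 1.1-fold higher number from compound 2 to compound 3 (0.04 log units; within the scatter). The 4-bromophenyl and the 3-chlorophenyl on a double-bonded chain carbon bound to a double-bonded ring carbon therefore stand level in this assay, so this exchange brings no step beyond the scatter. Nothing measured here offers an explanation for this result.

The exchange alters both the halogen and the number in the group's name, so this pair cannot show what either alteration does alone. Also open, from the compounds shown here alone, is whether a phenyl ring carrying an amine or a carboxylic acid at this place would stand level with these two compounds.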